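Trimming the ketone: from isopropyl to ethyl

The compounds below may be only part of what the source reports. "The series", "measured", "known", "first", "only" and "open" are said of these compounds alone.

Of the compounds shown here, three share a core and have been tested in an assay on HEK293 cells for positive allosteric modulation of metabotropic glutamate receptor 2 (Rattus norvegicus), read by thallium flux, with a stated time of 2.5 min; a lower number here means a smaller maximal response, a higher number a larger maximal response. Compound 1 `COc1cc(C(=O)O)ccc1OCCCCOc1ccc(C(=O)C(C)C)c(O)c1C` gives 73.1%. Compound 2 `Cc1cc(C(=O)O)ccc1OCCCCOc1ccc(C(=O)C(C)C)c(O)c1C` gives 76.9%, and compound 3 `Cc1c(OCCCCOc2ccc(C(=O)O)c(Cl)c2)ccc(C(=O)CC2CCCC2)c1O` gives 80.8%; neither value separates from that of compound 1 beyond the usual scatter, so compound 1 stands among the others rather than apart from them. Among the measured compounds shown here, the only single-point step measured, a number 3.8 percentage points higher from compound 1 to compound 2 (within the scatter), concerns an aromatic substituent. Compound 4 `CCC(=O)c1ccc(OCCCCOc2ccc(C(=O)O)cc2OC)c(C)c1O` differs from compound 1 elsewhere: hydrogen in place of methyl on a saturated chain carbon bound to a carbonyl carbon and a saturated chain carbon. For the measured compounds named here, no measured step touches this ketone side chain, so the expectation leans on the narrow spread of all three values. Compound 4 is therefore expected to show a number 0.9 percentage points higher from compound 1 to compound 4 (within the scatter), nothing beyond the scatter. The estimate for compound 4 is 74%, ranging from 60% to 88%.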

Compound 4, largest response reached (reported as percent of maximum), in percent of the reference or control that the assay uses: 86.5%
Beside the measured number, compound 4's estimate is 12.5 percentage points below it; the measured number falls inside the stated range.
By their numbers in this assay, from the lowest: compounds 1, 2, 3 and 4 (each within the scatter of the next, the first and the last beyond it).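

Isopropyl to ethyl at the ketone is the only single change shown that moves the number beyond the scatter in this assay: a number 13.4 percentage points higher from compound 1 to compound 4 (beyond the scatter). The earlier step, on an aromatic carbon, stayed within the scatter, so this saturated chain carbon bound to a carbonyl carbon is the one place shown where a single change registers, though only modestly. Nothing at hand explains the rise in maximal response. Going by these compounds, whether a still shorter acetyl group would continue this rise remains open, as does what an amine on this chain would give.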